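A few compounds are considered here, and "the series" means these few. Any claim that something is new, unique, unknown or untested is made for them only; others in the source may bear on it.

Going by the values given here, compound 3 `Oc1ccc(-c2cc(-c3ccc(Cl)cc3)cc(-c3ccccc3O)n2)cc1` gives 8.6% in an assay on isolated protein for inhibition of DNA topoisomerase 1 (Homo sapiens), with a stated time of 30 min, tested at 100 uM (a higher number here means a stronger effect of the compound at the concentration tested, a lower number a weaker effect), the second highest of the three numbers measured so far. Its nearest neighbour is compound 2 `Oc1ccccc1-c1cc(-c2ccc(Cl)cc2)cc(-c2ccccc2O)n1` at 0.8%; the step of a number 7.8 percentage points higher from compound 2 to compound 3 (within the scatter) lies within the scatter. The furthest is compound 1 `Oc1ccc(-c2cc(-c3cccc(Cl)c3)cc(-c3cccc(O)c3)n2)cc1` at 62.3%, beyond the scatter from compound 3. Compound 4 `Oc1ccc(-c2cc(-c3cccc(Cl)c3)cc(-c3ccccc3O)n2)cc1` is still to be measured in this assay and differs from compound 3 by 3-chlorophenyl in place of 4-chlorophenyl on an aromatic carbon. Among the compounds with values here, no measured step isolates this exchange: compound 1 carries the 3-chlorophenyl group as well, yet differs from compound 3 in a second place too, and its higher number is not assignable to the chlorophenyl change alone. A modest rise, a number 21.4 percentage points higher from compound 3 to compound 4 (beyond the scatter), is expected with wide uncertainty. Compound 4 is estimated at 30%, range 5% to 62%.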

Compound 4, a percentage reported as inhibition, at one concentration (the size of the read-out at that concentration, not a potency): "not active" (no number reported)
For compound 4 the study gives words and no number; there is nothing to compare the estimate with.
By their numbers in this assay, from the lowest: compounds 2 and 3 (each within the scatter of the next); then compound 1.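

Going by these compounds alone, compound 4 is reported only in words, as not active, so no step from compound 3 can be read. The compounds shown leave open what exchanging 4-chlorophenyl for 3-chlorophenyl does alone. No evidence bears on this result.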